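Replacing 4-methoxyphenyl with cyclopent-1-en-1-yl on the shared core

This account rests on a few compounds, and the source may have more. Where it says the series, first, only, none or still open, it means among the compounds named here.

Measured in an ADME assay (liver) for metabolic stability, with Liver microsome (Rattus norvegicus) as the target, using microsomes (a higher number here means faster removal of the compound, a lower number slower removal), so far:
- compound 1 `O=C(O)c1csc(-n2nc(-c3ccc(F)cc3)c3ccccc32)n1` gives 278 mL/min/kg
- compound 2 `O=C(O)c1csc(-n2nc(-c3cccc(F)c3)c3ccccc32)n1` gives 385 mL/min/kg
- compound 3 `COc1ccc(-c2nn(-c3nc(C(=O)O)cs3)c3ccccc23)cc1` gives 618 mL/min/kg

Within the data shown here, compound 3 stands clearly apart only from compound 1, with a 2.2-fold higher number from compound 1 to compound 3 (0.35 log units; beyond the scatter) as the one step beyond the scatter, while a 1.6-fold higher number from compound 2 to compound 3 (0.21 log units; within the scatter) stays inside it. Compound 4 `O=C(O)c1csc(-n2nc(C3=CCCC3)c3ccccc32)n1` carries cyclopent-1-en-1-yl in place of 4-methoxyphenyl on an aromatic carbon and so loses the six-membered aromatic ring of carbon only. Among the measured compounds shown here, no measured step makes such a swap. The nearest guides are those two steps and a 1.4-fold higher number from compound 1 to compound 2 (0.14 log units; within the scatter) in the same place, and none is large. A similarly small move in this assay is expected, landing among the three values. The estimated step is a 1.8-fold lower number from compound 3 to compound 4 (0.25 log units; within the scatter) as a modest expectation. For compound 4 the estimate is 350 mL/min/kg with an expected range from 170 mL/min/kg to 700 mL/min/kg overall.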

Compound 4, clearance: 196 mL/min/kg
The estimate for compound 4 lay 1.8-fold (0.25 log units) above the measured number; low and high end bracket the measured number.
By their numbers in this assay, from the lowest: compounds 4, 1, 2 and 3 (each within the scatter of the next, the first and the last beyond it).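

In this assay, among these compounds, this position accepts a non-aromatic ring, and cyclopent-1-en-1-yl replacing 4-methoxyphenyl gives the one step from compound 4 beyond the scatter (a 3.2-fold lower number from compound 3 to compound 4 (0.50 log units; beyond the scatter)). Replacing 3-fluorophenyl (a 2.0-fold lower number from compound 2 to compound 4 (0.29 log units; within the scatter)) or 4-fluorophenyl (a 1.4-fold lower number from compound 1 to compound 4 (0.15 log units; within the scatter)) stays within it, so the change separates compound 4 clearly only from the 4-methoxyphenyl compound. Nothing measured here gives a reason for these steps. From the compounds shown here alone, whether the double bond of cyclopent-1-en-1-yl matters remains open, since no saturated cyclopentyl ring appears for comparison. Going by these compounds, how an amine or a longer chain would behave at this position also remains open.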